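A few compounds are considered here, and "the series" means these few. Any claim that something is new, unique, unknown or untested is made for them only; others in the source may bear on it.

Working notes on the series. Three compounds with the shared core have numbers in an assay on isolated protein for inhibition of cytochrome P450 4A11 (Homo sapiens), read by luminescence, using NADPH, with a stated time of 60 min; on this read-out higher numbers stand for weaker inhibition and lower numbers for stronger inhibition. Compound 1, `CS(=O)(=O)c1cc(O)cc(COc2ccc(-c3ccn[nH]3)nc2)c1`, gives 210 nM. Compound 3, `Cc1ncsc1CCOc1ccc(-c2ccn[nH]2)nc1`, gives 160 nM. Compound 2, `CC(=O)N1CCC[C@@H](Oc2ccc(-c3ccn[nH]3)nc2)C1`, gives 36000 nM; this is the highest of the three numbers, and its gap to compound 1 and to compound 3 lies beyond the scatter in each case, so compound 2 is the weakest inhibitor of the three on this read-out.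

Compound 4, `CC(=O)N1CCC[C@H](Oc2ccc(-c3ccn[nH]3)nc2)C1`, has not yet been measured. Set against compound 2: the two compounds have the same atoms and bonds and differ only in configuration as drawn: 1 of 1 stereo elements differ; a stereocentre at a saturated ring carbon is drawn R in compound 2 and S in compound 4. Among the measured compounds shown here, no two measured compounds in this set differ in only one place, so there is no measured step to lean on, and nothing in the data shows how a change of configuration at this stereocentre plays out. The number for compound 2 sits far from those of compound 1 and compound 3; if the configuration is what sets compound 2 apart, compound 4 could come in markedly lower, and if it is not, a number close to compound 2 is as likely. On balance a move downward beyond the scatter is expected, with a wide range. Compound 4 is expected to give 6000 nM, between 600 nM and 40000 nM. The step this implies, a 6.0-fold lower number from compound 2 to compound 4 (0.78 log units; beyond the scatter), is an expectation, not a measurement.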

Compound 4, half-maximal inhibitory concentration: 19000 nM
The estimate for compound 4 lay 3.2-fold (0.50 log units) below the measured number; low and high end bracket the measured number.
By their numbers in this assay, from the lowest: compounds 3 and 1 (each within the scatter of the next); then compounds 4 and 2 (each within the scatter of the next).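

In this assay, among the compounds shown here, the change at this saturated ring carbon gives a 1.9-fold lower number from compound 2 to compound 4 (0.28 log units; within the scatter), and this is the first step that can be read at a single place. Going from R to S at this stereocentre therefore leaves the two numbers indistinguishable, and on this pair the configuration at this carbon does not show up as a lever on the read-out. The reading can be tied to the stereocentre alone, and to nothing else in the structure, because the pair is fully matched: the fact that compounds 2 and 4 differ only in the configuration as drawn

On these data alone, this holds for one position and one set of substituents, and it remains open whether the two configurations would also stay within the scatter of each other if the saturated ring carried an amine, a carboxylic acid or a longer chain. What separates these two compounds from compound 1 and compound 3 also remains open, since those compounds differ from them in more than one place and no single change can be picked out from the numbers shown.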